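The source may hold more compounds than are shown below. What is called first, only, known or untested is meant among the compounds shown, and "the series" means these compounds.

Compound 1 `COc1ccc(Br)cc1S(=O)(=O)Nc1cccnc1`: 43 nM
Compound 2 `COc1ccc(C(F)(F)F)cc1S(=O)(=O)Nc1cccnc1`: 183 nM
Compound 3 `COC(=O)c1ccc(OC)c(S(=O)(=O)Nc2cccnc2)c1`: 1510 nM

In an assay on isolated protein for inhibition of alkaline phosphatase, tissue-nonspecific isozyme (Homo sapiens) (a lower number here means a stronger inhibitor, a higher number a weaker inhibitor), compound 1 gives the lowest of the three numbers shown. Its nearest neighbour is reached by a 4.3-fold higher number from compound 1 to compound 2 (0.63 log units; beyond the scatter), and the widest gap by a 35-fold higher number from compound 1 to compound 3 (1.55 log units; beyond the scatter); between the other two compounds the step is an 8.3-fold higher number from compound 2 to compound 3 (0.92 log units; beyond the scatter). All three measured steps exchange the group on one aromatic ring of the shared core, the ring that carries the methoxy group.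

Compound 4 `COc1ccc(Br)cc1S(=O)(=O)Nc1cncc(C(N)=O)c1` differs from compound 1 in another place: carbamoyl in place of hydrogen on an aromatic carbon. Within the data shown here, the ring that receives this group is untouched in every measured step, so none of them bears directly on the change, and the measured series offers no precedent for it. With nothing to point in either direction, the step is expected to stay near the scatter, and the estimate leans only slightly toward a higher number: a 1.9-fold higher number from compound 1 to compound 4 (0.27 log units; within the scatter) is expected. Compound 4 is therefore estimated at 80 nM, with a range from 20 nM to 400 nM.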

Compound 4, half-maximal inhibitory concentration: 14 nM
Compound 4: the middle estimate sits 5.7-fold (0.76 log units) above what was measured; the whole stated range lies above it.
By their numbers in this assay, from the lowest: compound 4; then compound 1; then compound 2; then compound 3.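

In this assay, among these compounds, the six-membered aromatic ring with 1 nitrogen, which no earlier step had touched, proves able to carry a substituent: carbamoyl placed two atoms from the ring nitrogen and meta to a large group gives a 3.1-fold lower number from compound 1 to compound 4 (0.49 log units; beyond the scatter). The earlier steps changed only the ring bearing the methoxy group, and both steps away from compound 1 raised the number, so this is the first change shown that lowers it from compound 1. Nothing available explains why the number falls with this change.

As far as these compounds go, whether the gain is specific to carbamoyl remains open, since a carboxylic acid, a nitrile or an amine at the same place could behave differently. Also open, from the compounds shown here alone, is whether the gain would carry over to the trifluoromethyl or methoxycarbonyl analogues, compound 2 and compound 3.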